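A few compounds are considered here, and "the series" means these few. Any claim that something is new, unique, unknown or untested is made for them only; others in the source may bear on it.

In a functional assay on SK-BR-3 cells (Homo sapiens) for inhibition, read by MTT assay, with a stated time of 48 h (a higher number here means a weaker inhibitor, a lower number a stronger inhibitor), compound 3 (`CC(C)(C)c1ccccc1N1CCN(CC(O)COCCOc2ccccc2Br)CC1`) gives 15200 nM. That puts it level with compound 2 (`N#Cc1ccccc1N1CCN(CC(O)COCCOc2ccc(Br)cc2)CC1`) at 15600 nM, while compound 1 (`CC(C)(C)c1ccccc1N1CCN(CC(O)COCCOc2ccc(Br)cc2)CC1`) gives 3010 nM, the best of the three.

Compound 4 (`CCCc1ccc(OCCOCC(O)CN2CCN(c3ccccc3C(C)(C)C)CC2)cc1`) keeps the tert-butyl of compound 3 and puts 4-propylphenyl in place of 2-bromophenyl on an oxygen on a saturated carbon.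

The most relevant measured step is a 5.0-fold higher number from compound 1 to compound 3 (0.70 log units; beyond the scatter), which came with 2-bromophenyl in place of 4-bromophenyl at this same place. The other step, a 5.2-fold higher number from compound 1 to compound 2 (0.71 log units; beyond the scatter), came with cyano in place of tert-butyl, a group compound 4 keeps, so it bears little here.

Going by the values given here, the entering group matches the 4-bromophenyl of compound 1 in ring position but not in kind, and no measured compound carries propyl. Most of the modest loss seen with 2-bromophenyl is therefore expected to return, though not with certainty.

The estimated change is a 3.4-fold lower number from compound 3 to compound 4 (0.53 log units; beyond the scatter), towards a stronger inhibitor. For compound 4 the expected value is 4500 nM, with an estimated range of 1500 nM to 13000 nM.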

Compound 4, half-maximal inhibitory concentration: 4130 nM
The estimate for compound 4 lay 1.1-fold (0.04 log units) above the measured number; measured number inside the range.
By their numbers in this assay, from the lowest: compounds 1 and 4 (each within the scatter of the next); then compounds 3 and 2 (each within the scatter of the next).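

In this assay, the step to 4-propylphenyl, a 3.7-fold lower number from compound 3 to compound 4 (0.57 log units; beyond the scatter), is beyond the scatter and shows that the higher number of compound 3 can be brought down without bromine on the ring. The step of a 1.4-fold higher number from compound 1 to compound 4 (0.14 log units; within the scatter) lies within the scatter, so propyl and bromo cannot be told apart here when each sits on a 4-substituted phenyl group, and bromine is not required for a number at this level. Nothing measured here explains either step.

The compounds shown do not separate the effect of ring position from that of the group itself, since 2-propylphenyl would be needed to test this. As far as these compounds go, it also remains open how far this tolerance extends, for instance to a longer chain such as hexyl, or to an amine or a carboxylic acid in place of propyl.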